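The source may hold more compounds than are shown below. What is called first, only, known or untested is meant among the compounds shown, and "the series" means these compounds.

- Compound 1 `CCCCn1nc(C(=O)N[C@H]2COc3ccccc3N(C)C2=S)nc1Cc1ccccc1` gives 510 nM
- Compound 2 `CN1C(=S)[C@@H](NC(=O)c2nc(Cc3ccccc3)n(CCCF)n2)COc2ccccc21` gives 4760 nM

Both values come from a functional assay on HT-29 cells (Homo sapiens) for inhibition, read by luminescence and CellTiter-Glo, with a stated time of 24 h; on this read-out higher numbers stand for an effect only at larger amounts of compound and lower numbers for an effect already at smaller amounts. Compound 2 has the higher of the two numbers, so it needs the larger amount to act. Compound 3 `CN1C(=S)[C@@H](NC(=O)c2nc(Cc3ccccc3)n(CCCC(F)(F)F)n2)COc2ccccc21` differs from compound 2 in one place: trifluoromethyl in place of fluoro on a saturated chain carbon, three bonds along the chain from an aromatic nitrogen. In words, it has trifluoromethyl in place of fluoro on a saturated chain carbon, three bonds along the chain from an aromatic nitrogen. For the measured compounds named here, only one measured step bears on this change, at the same place: a 9.3-fold higher number from compound 1 to compound 2 (0.97 log units; beyond the scatter). There, fluoro replaced methyl, and the number rose beyond the scatter. Compound 3 again has a carbon group at that place, so a partial return towards the lower number is expected, although one step is thin evidence. The estimate is a 3.2-fold lower number from compound 2 to compound 3 (0.50 log units; beyond the scatter). Compound 3 is expected to give about 1500 nM, within an estimated range of 400 nM to 5000 nM.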

Compound 3, half-maximal effective concentration: 2380 nM
Compound 3: the middle estimate sits 1.6-fold (0.20 log units) below what was measured; low and high end bracket the measured number.
By their numbers in this assay, from the lowest: compound 1; then compounds 3 and 2 (each within the scatter of the next).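

In this assay, the chain ending in trifluoromethyl cannot be told apart from the one ending in fluoro: a 2.0-fold lower number from compound 2 to compound 3 (0.30 log units; within the scatter) is a difference no larger than repeat measurements can produce. Set against the chain ending in methyl, however, the trifluoromethyl end still shows a clear gap, with a 4.7-fold higher number from compound 1 to compound 3 (0.67 log units; beyond the scatter) as the step, so among these three compounds both fluorinated chain ends lie apart from the plain butyl chain of compound 1, and neither goes against this. Nothing shown explains this gap between the fluorinated chains and the butyl chain.

Still open, going by these compounds, is how this place responds to a longer chain, such as pentyl, with no fluorine on it. An amine or a carboxylic acid at the chain end is equally untested by the compounds shown here.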